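From 3-chlorobenzyl to 4-fluorobenzyl in compound 4

The source may report more compounds than this note shows. Statements on the series, on what has been measured and on what is new or still open speak of the compounds shown alone.

In a functional assay on MCF7 cells (Homo sapiens) for cytotoxicity, read by MTT assay, with a stated time of 24 h (on this read-out lower numbers stand for stronger inhibition and higher numbers for weaker inhibition), compound 2 (`O=C1/C(=C/c2ccccc2F)CN(Cc2cn(Cc3cccc(Cl)c3)nn2)C/C1=C\c1ccccc1F`) reads 12000 nM and sits within the scatter of compound 1 (`O=C1/C(=C/c2ccccc2F)CN(Cc2cn(Cc3ccccc3F)nn2)C/C1=C\c1ccccc1F`), which reads 6000 nM here. Compound 3 (`Cc1ccc(/C=C2\CN(C(=S)SCc3cn(Cc4ccc(F)cc4)nn3)C/C(=C\c3ccc(C)cc3)C2=O)cc1`) reads 81600 nM and stands clearly above compound 2 on these numbers. Compound 4 (`O=C1/C(=C/c2ccccc2F)CN(Cc2cn(Cc3ccc(F)cc3)nn2)C/C1=C\c1ccccc1F`) carries 4-fluorophenyl in place of 3-chlorophenyl on a saturated chain carbon bound to an aromatic nitrogen, that is, 3-chlorobenzyl to 4-fluorobenzyl. For the measured compounds named here, the only measured step at this place, 3-chlorophenyl in place of 2-fluorophenyl, gave a 2.0-fold higher number from compound 1 to compound 2 (0.30 log units; within the scatter) and nothing beyond the scatter. No step beyond the scatter is therefore expected in this assay for this change. The expected step is a 1.3-fold lower number from compound 2 to compound 4 (0.12 log units; within the scatter) and stays within the scatter. Compound 4 is estimated at 9000 nM with an expected range (4000 nM to 20000 nM).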

Compound 4, half-maximal inhibitory concentration: 6000 nM
Compound 4: the middle estimate sits 1.5-fold (0.18 log units) above what was measured; the range from low to high includes it.
By their numbers in this assay, from the lowest: compounds 1, 4 and 2 (each within the scatter of the next); then compound 3.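

In this assay the step of a 2.0-fold lower number from compound 2 to compound 4 (0.30 log units; within the scatter) and the step of no change at the digits printed from compound 1 to compound 4 (within the scatter) both stay within the scatter. On a saturated chain carbon bound to an aromatic nitrogen, 2-fluorophenyl, 3-chlorophenyl and 4-fluorophenyl therefore cannot be told apart, which now holds across three substituted phenyl groups rather than two. No measured evidence bears on a cause for this. Going by these compounds, whether an amine, a carboxylic acid or a longer chain at this place would give a step beyond the scatter stays open. Compound 3 differs from the others in more than one place and does not settle this.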